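A few compounds are considered here, and "the series" means these few. Any claim that something is new, unique, unknown or untested is made for them only; others in the source may bear on it.

Measured so far in a functional assay on A549 cells (Homo sapiens) for antiproliferative activity, read by MTT assay, with a stated time of 48 h (on this read-out higher numbers stand for weaker inhibition and lower numbers for stronger inhibition), for the series:
- compound 1 `COc1ccc(/C=C/c2cc(OC)cc(OC)c2/C=C/C(=O)c2ccc(Cl)c(Cl)c2)cc1` gives 5.9 ug/mL
- compound 2 `COc1ccc(/C=C/c2cc(OC)cc(OC)c2/C=C/C(=O)c2cccc(Br)c2)cc1` gives 8.1 ug/mL
- compound 3 `COc1ccc(/C=C/c2cc(OC)cc(OC)c2/C=C/C(=O)c2ccc(C(F)(F)F)cc2)cc1` gives 7.8 ug/mL

Compound 3 cannot be separated from the other two: a 1.0-fold lower number from compound 2 to compound 3 (0.02 log units; within the scatter) and a 1.3-fold higher number from compound 1 to compound 3 (0.12 log units; within the scatter) are both within the scatter, and a 1.4-fold higher number from compound 1 to compound 2 (0.14 log units; within the scatter) is too. The three values therefore form no order.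

Compound 4 `COc1ccc(/C=C/c2cc(OC)cc(OC)c2/C=C/C(=O)c2ccc(Cl)cc2)cc1` departs from compound 3 at one place chloro in place of trifluoromethyl on an aromatic carbon with chloro in place of trifluoromethyl on an aromatic carbon, para to a large group. Within the data shown here, no measured step makes this exact change. The closest evidence is the pair of steps reaching compound 3, which bring in 4-(trifluoromethyl)phenyl for 3,4-dichlorophenyl and for 3-bromophenyl. Neither leaves the scatter, and no change at this aryl group has done so yet. In this assay a step of a 1.1-fold lower number from compound 3 to compound 4 (0.05 log units; within the scatter) is therefore expected, within the scatter and with no firm direction. For compound 4 the estimate is 7 ug/mL with an expected range from 4 ug/mL to 12.5 ug/mL in this series.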

Compound 4, half-maximal inhibitory concentration: 6.4 ug/mL
The estimate for compound 4 lay 1.1-fold (0.04 log units) above the measured number; measured number inside the range.
By their numbers in this assay, from the lowest: compounds 1, 4, 3 and 2 (each within the scatter of the next).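

In this assay the exact change at this place, on an aromatic carbon para to a large group, now has a direct reading: chloro in place of trifluoromethyl gives a 1.2-fold lower number from compound 3 to compound 4 (0.09 log units; within the scatter) and stays within the scatter. Hydrogen in place of chloro gives a 1.1-fold higher number from compound 1 to compound 4 (0.04 log units; within the scatter) and 4-chlorophenyl in place of 3-bromophenyl gives a 1.3-fold lower number from compound 2 to compound 4 (0.10 log units; within the scatter) so neither the loss of one chloro nor the swap to a different aryl pattern separates compound 4, and the four aryl groups still form no order. Nothing available explains this flat picture.

Open, as far as these compounds go, is whether an amine or a carboxylic acid on this aromatic carbon would give a step beyond the scatter. Also open, from the compounds shown here alone, is whether any aryl group on the carbonyl can separate itself from the others.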